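Acetyl in place of 4-nitrophenyl: an unmeasured step

This account rests on a few compounds, and the source may have more. Where it says the series, first, only, none or still open, it means among the compounds named here.

Measured so far:
compound 1 `O=C(CCCCCCc1ccccc1)c1ncc(-c2ccc([N+](=O)[O-])cc2)o1` — 50 nM
compound 2 `O=C(CCCCCCc1ccccc1)c1ncc(-c2cnc(C(=O)CCCCCCc3ccccc3)o2)o1` — 3500 nM

In an assay (Rattus norvegicus) for inhibition of Fatty-acid amide hydrolase 1 (Homo sapiens) (a lower number here means a stronger inhibitor, a higher number a weaker inhibitor), compound 1 gives 50 nM, the lowest of the two numbers; compound 2 gives 3500 nM, a gap beyond the scatter. Compound 3 `CC(=O)c1cnc(C(=O)CCCCCCc2ccccc2)o1` is not yet measured. It differs from compound 1 as follows: acetyl in place of 4-nitrophenyl on an aromatic carbon. Going by the values given here, no step between measured compounds covers this change, so the expectation rests on compound 1 alone. A weakening of modest size, beyond the scatter, is expected in this assay: a 6.0-fold higher number from compound 1 to compound 3 (0.78 log units; beyond the scatter). Compound 3 is estimated at 300 nM, within 60 nM to 1500 nM.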

Compound 3, inhibition constant: 2 nM
Compound 3: middle estimate off by 150-fold (2.18 log units), on the high side; measured number below the stated range.
By their numbers in this assay, from the lowest: compound 3; then compound 1; then compound 2.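

In this assay, the position next to the ring oxygen tolerates a far smaller group than 4-nitrophenyl, and acetyl there gives a 25-fold lower number from compound 1 to compound 3 (1.40 log units; beyond the scatter). The six-membered aromatic ring and its nitro group are therefore not required for a low number: compound 3 gives 2 nM. No measured evidence bears on the reason for this step.

Open, as far as these compounds go, is whether the acetyl carbonyl matters here, which an ethyl group or a methyl ester at this position would test. Also open, from the compounds shown here alone, is whether the step holds with a shorter or longer chain on the shared ketone.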